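Aryl replacement on the sulfonyl sulfur of a piperidinyl-piperidine sulfonamide

The source may hold more compounds than are shown below. What is called first, only, known or untested is meant among the compounds shown, and "the series" means these compounds.

Compound 3 `CC1CCN(C2CCN(S(=O)(=O)c3ccc(Cl)nc3)CC2)CC1` carries a 6-chloropyridin-3-yl group on the sulfonyl sulfur; in a functional assay on DLD-1 cells (Homo sapiens) for antiproliferative activity, read by CellTiter-Glo, with a stated time of 72 h (a higher number here means a weaker inhibitor, a lower number a stronger inhibitor), compound 3 gives 3700 nM, the highest of the two numbers recorded. Compound 2 `CC1CCN(C2CCN(S(=O)(=O)c3ccc(-c4ccccc4F)cc3)CC2)CC1` gives 5 nM in this assay, a gap beyond the scatter. Compound 1 `Cc1noc(C)c1S(=O)(=O)N1CCC(N2CCC(C)CC2)CC1` returns only a limit of this assay, > 5000 nM (the limit of > 5000 nM in this assay, at which 1 of the 3 values shown sits), not a number.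

Compound 4 `CCc1ccc(S(=O)(=O)N2CCC(N3CCC(C)CC3)CC2)cc1` differs from compound 3 in one place: 4-ethylphenyl in place of 6-chloropyridin-3-yl on a sulfonyl sulfur.

Going by the values given here, the single measured step, an at least 1.3-fold lower number from compound 1 to compound 3 (0.13 log units; that floor lies within the scatter), changes the same position but stays within the scatter, so it gives no size for the present change. The pairing of compound 2 at 5 nM with compound 3 at 3700 nM shows that a carbon-only aromatic ring on this sulfur can go with a far lower number, so a fall beyond the scatter is expected, a 31-fold lower number from compound 3 to compound 4 (1.49 log units; beyond the scatter). Compound 4 is therefore estimated at 120 nM in this assay, expected between 15 nM and 1000 nM.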

Compound 4, half-maximal inhibitory concentration: > 5000 nM
Compound 4 gave a limit, no number (the forecaster's own chance of this, stated with the estimate: 3%); middle value at least 41-fold (1.61 log units) from the limit.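

In this assay, a carbon-only aromatic ring on the sulfonyl sulfur does not by itself go with a low number: 4-ethylphenyl in place of 6-chloropyridin-3-yl gives an at least 1.3-fold higher number from compound 3 to compound 4 (0.13 log units; that floor lies within the scatter). The large step lies in the group carried on that ring: ethyl in place of 2-fluorophenyl on an aromatic carbon gives an at least 1000-fold higher number from compound 2 to compound 4 (3.00 log units; beyond the scatter), and among the compounds shown, only compound 2 has a low number. Compound 4 and compound 1 both stand at a limit, not a number, and the step between them cannot be read: the limit of > 5000 nM in this assay, at which 2 of the 4 values shown sit.

As far as these compounds go, it remains open whether an unsubstituted phenyl or a pyridine ring in place of 2-fluorophenyl would keep the low number of compound 2. From the compounds shown here alone, how an amine or a carboxylic acid on that aromatic carbon would read is also open.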